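This account rests on a few compounds, and the source may have more. Where it says the series, first, only, none or still open, it means among the compounds named here.

The three measured compounds share one core and differ only in the aryl group on the sulfonamide nitrogen. In a functional assay on cells (leukaemia cell line, Homo sapiens) for inhibition, read by sulforhodamine B assay, with a stated time of 48 h (a higher number here means that more compound is tolerated, a lower number that less compound is tolerated), compound 1 `O=S(=O)(Nc1ccc(F)c(Cl)c1)c1ccc(-c2cnc(C3CC3)o2)cc1` gives > 100000 nM, a limit of the assay rather than a number. Compound 2 `Cc1ccc(NS(=O)(=O)c2ccc(-c3cnc(C4CC4)o3)cc2)cc1C` likewise gives > 100000 nM, again a limit. Compound 3 `Cc1cc(Cl)ccc1NS(=O)(=O)c1ccc(-c2cnc(C3CC3)o2)cc1` also returns > 100000 nM, a limit. Compound 2 therefore stands where every value stands, at the limit of > 100000 nM in this assay, at which 3 of the 3 values shown sit. The steps a step that the two limits leave unreadable from compound 1 to compound 2, a step that the two limits leave unreadable from compound 1 to compound 3 and a step that the two limits leave unreadable from compound 2 to compound 3, each running between two limits, give no readable size. Compound 4 `Cc1cc(F)cc(NS(=O)(=O)c2ccc(-c3cnc(C4CC4)o3)cc2)c1` arises from compound 2 by 3-fluoro-5-methylphenyl in place of 3,4-dimethylphenyl on a sulfonamide nitrogen. For the measured compounds named here, no measured step bears readably on this change, so no shift beyond the scatter is expected. Compound 4 is estimated at 200000 nM, within 80000 nM to 500000 nM, an expected step that the limit leaves unreadable from compound 2 to compound 4.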

Compound 4, concentration lethal to 50% of the cells: 78100 nM
Compound 4: middle estimate off by 2.6-fold (0.41 log units), on the high side, outside the stated range (below it).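

For the compounds shown here, with 3-fluoro-5-methylphenyl on the sulfonamide nitrogen, compound 4 gives the first readable number of the series in this assay, so this position can leave the limit of the assay. The change yields an at least 1.2-fold lower number from compound 2 to compound 4 (0.10 log units; that floor lies within the scatter) and an at least 1.2-fold lower number from compound 3 to compound 4 (0.10 log units; that floor lies within the scatter) and an at least 1.2-fold lower number from compound 1 to compound 4 (0.10 log units; that floor lies within the scatter), which fixes only a floor on each step and not its true size. The limit still holds for most of the series: the limit of > 100000 nM in this assay, at which 3 of the 4 values shown sit.

On these data alone, whether an amine or a carboxylic acid at this position on the aryl group would give a number in this assay remains open.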